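This account rests on a few compounds, and the source may have more. Where it says the series, first, only, none or still open, it means among the compounds named here.

Compound 1 `O=c1ccoc2cc(OCc3cn(Cc4ccccc4)nn3)ccc12` and compound 2 `O=c1ccoc2cc(OCc3cn(Cc4cccc([N+](=O)[O-])c4)nn3)ccc12` share one core; compound 3 `N#Cc1cccc(Cn2cc(COc3ccc4c(=O)ccoc4c3)nn2)c1` is the unmeasured member. In a functional assay on QGY7701 cells (Homo sapiens) for cytotoxicity, read by MTT assay, with a stated time of 48 h (on this read-out lower numbers stand for stronger inhibition and higher numbers for weaker inhibition), compound 1 gives only a limit, > 100000 nM. Going by the values given here, compound 2 gives 14100 nM in this assay, the single number in the set. The step of an at least 7.0-fold lower number from compound 1 to compound 2 (0.85 log units; beyond the scatter) is bounded by the limit of > 100000 nM in this assay, at which 1 of the 2 values shown sits. Compound 3 differs from compound 2 by cyano in place of nitro on an aromatic carbon. Among the compounds with values here, no measured step exchanges one such group for another; the sole measured step replaced hydrogen with nitro. For compound 3 a modest weakening is expected, a 2.1-fold higher number from compound 2 to compound 3 (0.33 log units; beyond the scatter). The estimate for compound 3 is 30000 nM, ranging from 8000 nM to 100000 nM.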

Compound 3, half-maximal inhibitory concentration: 24400 nM
Estimate against measurement, compound 3: 1.2-fold (0.09 log units) above, and the stated range covers the measured number.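

In this assay, the change from 3-nitrophenyl to 3-cyanophenyl gives a 1.7-fold higher number from compound 2 to compound 3 (0.24 log units; within the scatter), so a second group at this place can stand in for nitro without a step beyond the scatter. Cyano in place of hydrogen also gives a step, an at least 4.0-fold lower number from compound 1 to compound 3 (0.61 log units; beyond the scatter), so the lower number seen with nitro is not confined to nitro. Both steps from compound 1 rest on a limit, not a number: the limit of > 100000 nM in this assay, at which 1 of the 3 values shown sits.

From the compounds shown here alone, whether an amine, a carboxylic acid or a methoxy group at this place would behave like nitro and cyano stays open. So does how far below compound 1 the true values of these steps lie.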